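The source may report more compounds than this note shows. Statements on the series, on what has been measured and on what is new or still open speak of the compounds shown alone.

Working notes on a set of pyrazolone-derived anilides

Compound 1 `Cc1cc(=O)n(-c2ccccc2OC(F)(F)F)nc1C(=O)Nc1ccc(Oc2ncnc3ccsc23)c(F)c1`, compound 2 `Cc1cc(=O)n(-c2cccc(F)c2)nc1C(=O)Nc1ccc(Oc2ncnc3ccsc23)c(F)c1` and compound 3 `Cc1cc(=O)n(-c2ccccc2OC(F)(F)F)nc1C(=O)Nc1ccc(Oc2ncnc3sccc23)cc1` have been measured; compound 4 `Cc1cc(=O)n(-c2cccc(F)c2)nc1C(=O)Nc1ccc(Oc2ncnc3sccc23)cc1` has not. All three measured compounds were run in a functional assay on MCF7 cells (Homo sapiens) for cytotoxicity, read by MTT assay, with a stated time of 72 h; a higher number here means a weaker inhibitor, a lower number a stronger inhibitor. In this assay compound 1 gives 11500 nM, compound 2 gives 9050 nM and compound 3 gives 11000 nM. The three numbers sit close together, and none of the compounds can be singled out as stronger or weaker than the others on this evidence.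

One structural change recurs. From compound 1 to compound 2 the change is 3-fluorophenyl in place of 2-(trifluoromethoxy)phenyl on an aromatic nitrogen, and it produced a 1.3-fold lower number from compound 1 to compound 2 (0.10 log units; within the scatter). The same kind of change, (3-fluorophenyl in place of 2-(trifluoromethoxy)phenyl on an aromatic nitrogen), carries compound 3 to compound 4; the two place descriptions read the same word for word. The cores of compound 1 and compound 3 differ, but the difference between the two cores is not broken down here.

Among the measured compounds shown here, for compound 4 the expectation rests on the one earlier instance: since the change from compound 1 to compound 2 gave a 1.3-fold lower number from compound 1 to compound 2 (0.10 log units; within the scatter), a step of about a 1.3-fold lower number from compound 3 to compound 4 (0.10 log units; within the scatter) is expected from compound 3 to compound 4 in this assay. Compound 4 is therefore estimated at 8700 nM in this assay, with a likely range from 4500 nM to 17000 nM, which overlaps the value of compound 3 once the usual scatter is allowed for.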

Compound 4, half-maximal inhibitory concentration: 27200 nM
Compound 4: the middle estimate sits 3.1-fold (0.50 log units) below what was measured; measured number outside the range, above it.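

In this assay, placing 3-fluorophenyl where 2-(trifluoromethoxy)phenyl stood on the core of compound 3 gave a 2.5-fold higher number from compound 3 to compound 4 (0.39 log units; beyond the scatter), and the two cores do not share one step size for this change: the same change on two cores in this assay, a 1.3-fold lower number (0.10 log units; within the scatter) from compound 1 to compound 2 and a 2.5-fold higher number (0.39 log units; beyond the scatter) from compound 3 to compound 4, 3.1-fold (0.50 log units) apart, beyond the scatter of two such steps

For these two pairs, then, a step read on the core of compound 1 is not a reliable guide to the same change on the core of compound 3, and the swap has to be judged on each core separately. Among the compounds shown here, with only two pairs in a single cell assay, this does not show which part of the core difference goes with the split, why the steps part, or whether either step would hold on any further core.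

Still open is which of the differences between the two cores tracks with the divergence, since the pairs shown do not break that difference down. Also open, going by these compounds, is how a plain phenyl or a cyclohexyl on that aromatic nitrogen would behave on each core, and whether such groups would follow the pattern of compound 2 or that of compound 4.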